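This account rests on a few compounds, and the source may have more. Where it says the series, first, only, none or still open, it means among the compounds named here.

Measured so far:
compound 1 `Nc1ccccc1NC(=O)CCCNCC(=O)Nc1cc(Cl)ccc1Cl`: > 100000 nM
compound 2 `Cc1ccc(NC(=O)CNc2ccc(C(=O)Nc3ccccc3N)cc2)cc1`: > 100000 nM

In a functional assay on U-251 cells (Homo sapiens) for inhibition, read by MTT assay, with a stated time of 2 days (a lower number here means a stronger inhibitor of growth, a higher number a weaker inhibitor of growth), compound 1 gives > 100000 nM, which is a limit of the assay and not a number. Compound 2 gives > 100000 nM in this assay, likewise a limit. Both values sit at the limit of > 100000 nM in this assay, at which 2 of the 2 values shown sit, so compound 1 stands at the limit with no number to place it. Compound 3 `Nc1ccccc1NC(=O)CCCNCC(=O)Nc1cccc(Cl)c1` differs from compound 1 by hydrogen in place of chloro on an aromatic carbon. Within the data shown here, no measured step carries this change, and a starting point at the limit leaves no direction to read, so no move beyond the scatter in this assay is expected. Compound 3 is expected to give 100000 nM, between 30000 nM and 300000 nM, most likely reported again as a limit. The step of a number no higher from compound 1 to compound 3 (the limit leaves the size open) is thus expected to be about nil.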

Compound 3, concentration for total growth inhibition: > 100000 nM
Compound 3: a limit, no number; the forecaster's own chance of this, stated with the estimate: 80%; the middle value lies on the limit itself.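

Compound 3 stands at a limit, as compound 1 does, so no step between compound 1 and compound 3 can be read: the limit of > 100000 nM in this assay, at which 3 of the 3 values shown sit.

The compounds shown leave open whether hydrogen in place of chloro changes growth inhibition at all, as none of them gives a number.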